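A few compounds are considered here, and "the series" means these few. Any claim that something is new, unique, unknown or untested is made for them only; others in the source may bear on it.

Values measured in an ADME assay on HEL cells (Homo sapiens) for cytotoxicity, with a stated time of 3 days (a higher number here means that more compound is tolerated, a lower number that less compound is tolerated), follow
- Compound 1 `Cc1cc(-c2ccc(O)cc2)cn2c(CSCCc3ccccc3)cnc12` gives > 50 ug/mL
- Compound 2 `Cc1cc(-c2ccsc2)cn2c(CSCCc3ccccc3)cnc12` gives > 50 ug/mL
- Compound 3 `Cc1cc(-c2cccc(C#N)c2)cn2c(CSCCc3ccccc3)cnc12` gives > 50 ug/mL

Compound 3 reads > 50 ug/mL, which is a limit of this assay and not a number. The same holds for compound 1 and compound 2, so the set offers the limit of > 50 ug/mL in this assay, at which 3 of the 3 values shown sit, and no ranking.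

Compound 4 `Cc1cc(-c2ccc(C#N)cc2)cn2c(CSCCc3ccccc3)cnc12` carries 4-cyanophenyl in place of 3-cyanophenyl on an aromatic carbon of the shared core, and the two have the same atoms, joined differently: 4-cyanophenyl in place of 3-cyanophenyl on an aromatic carbon.

Three measured swaps at this same carbon bear on the change. They are a step that the two limits leave unreadable from compound 1 to compound 3, a step that the two limits leave unreadable from compound 2 to compound 3 and a step that the two limits leave unreadable from compound 1 to compound 2. None of them gives a size to carry over. With compound 3 at its limit of > 50 ug/mL as the closest guide, no step beyond the usual scatter is expected, and another limit reading is likely. The expected change is a number no higher from compound 3 to compound 4 (the limit leaves the size open). Compound 4 is estimated at 50 ug/mL, with an expected range from 25 ug/mL to 100 ug/mL.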

Compound 4, half-maximal cytotoxic concentration: 10.6 ug/mL
For compound 4 the middle estimate is 4.7-fold (0.67 log units) above the measured one, outside the stated range (below it).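

Swapping 3-cyanophenyl for 4-cyanophenyl, with the same atoms joined differently, gives an at least 4.7-fold lower number from compound 3 to compound 4 (0.67 log units; beyond the scatter), which shows that in this assay the place of the nitrile on this ring can change the reading. The other two swaps at this carbon also give readable steps: 4-cyanophenyl in place of thiophen-3-yl gives an at least 4.7-fold lower number from compound 2 to compound 4 (0.67 log units; beyond the scatter), and cyano in place of hydroxy gives an at least 4.7-fold lower number from compound 1 to compound 4 (0.67 log units; beyond the scatter). The steps among the three earlier compounds cannot be read, and the new steps give only a smallest possible size: the limit of > 50 ug/mL in this assay, at which 3 of the 4 values shown sit.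

Going by these compounds, it remains open how other groups on this phenyl ring, such as an amine or a carboxylic acid, would read at this carbon. On these data alone, the full size of each step also stays open, as the reading on the far side of each is a limit and not a number.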